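Swapping the group on nitrogen in compound 1

The source may report more compounds than this note shows. Statements on the series, on what has been measured and on what is new or still open speak of the compounds shown alone.

In a physicochemical assay for solubility, in phosphate buffer, measured as kinetic solubility, with a stated time of 1 h, at pH 7.4 (a lower number here means a less soluble compound, a higher number a more soluble compound), compound 1 (`CNCC(=O)Nc1ccc(-c2nc(C(C)(C)S(C)(=O)=O)cc([C@]34CCOC[C@H]3C4)n2)cc1`) gives 217 ug/mL and compound 2 (`CNCC(=O)Nc1ccc(-c2nc(CS(C)(=O)=O)cc([C@]34CCOC[C@H]3C4)n2)cc1`) gives 158 ug/mL, two values within the usual scatter of each other, while compound 3 (`CCNC(=O)Nc1ccc(-c2nccc(C3=CCOCC3)n2)cc1`) gives a much lower 24 ug/mL. Compound 4 (`CC(C)(c1cc([C@]23CCOC[C@H]2C3)nc(-c2ccc(NC(=S)NCCO)cc2)n1)S(C)(=O)=O`) alters compound 1 at one place: a group of 6 heavy atoms (3 carbon, 1 nitrogen, 1 oxygen, 1 sulfur; no ring) in place of a group of 5 heavy atoms (3 carbon, 1 nitrogen, 1 oxygen; no ring), on a nitrogen on an aromatic ring. Among the measured compounds shown here, the only measured step, a 1.4-fold lower number from compound 1 to compound 2 (0.14 log units; within the scatter), sits on an aromatic carbon, so it offers no direct guide to a change on this nitrogen. The low number of compound 3, 24 ug/mL, shows that much lower values occur here, so a drop is expected, though with wide uncertainty. The estimated change in this assay is a 4.8-fold lower number from compound 1 to compound 4 (0.68 log units; beyond the scatter). For compound 4 the expected value is 45 ug/mL, within a range from 12 ug/mL to 150 ug/mL.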

Compound 4, solubility: 173 ug/mL
Estimate against measurement, compound 4: 3.8-fold (0.58 log units) below, and the stated range ends below it.
By their numbers in this assay, from the lowest: compound 3; then compounds 2, 4 and 1 (each within the scatter of the next).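

In this assay, the exchange on a nitrogen on an aromatic ring gives a 1.3-fold lower number from compound 1 to compound 4 (0.10 log units; within the scatter), the first step read at this position. Here, a sulfur-containing group with no ring stands in place of ((methylamino)methyl)carbonyl, and the two numbers stay within the scatter of each other. Nothing measured here accounts for this result. This single exchange leaves open how other groups on this nitrogen would read in the same assay, such as a carboxylic acid or a longer chain ending in an amine.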